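Hydroxy on the propyl chain of compound 1

The source may hold more compounds than are shown below. What is called first, only, known or untested is meant among the compounds shown, and "the series" means these compounds.

Of the compounds shown here, three have numbers so far. In a functional assay on NCI-H1975 cells (Homo sapiens) for antiproliferative activity, read by CCK-8 assay, with a stated time of 72 h (on this read-out lower numbers stand for stronger inhibition of growth and higher numbers for weaker inhibition of growth), compound 1 (`CCCNS(=O)(=O)c1ccc(Nc2ncc3c(n2)N(c2ccn(C)n2)C(CC)C(=O)N3C)cc1`) gives 21700 nM and compound 3 (`CCCCNC(=O)c1ccc2c(ccn2-c2ncc3c(n2)N(c2ccn(C)n2)C(CC)C(=O)N3C)c1`) gives 12000 nM as well, two numbers within the scatter of each other. Compound 2 (`CCCNS(=O)(=O)c1ccc(Nc2ncc3c(n2)N(C2CCCC2)[C@H](CC)C(=O)N3C)cc1`) gives 2100 nM and lies beyond the scatter from compound 1, on the side of stronger inhibition of growth. For the measured compounds named here, neither compound 2 nor compound 3 differs from compound 1 in one place only, so the series offers no measured step to serve as a guide for the change considered here.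

Compound 4 (`CCC1C(=O)N(C)c2cnc(Nc3ccc(S(=O)(=O)NCCCO)cc3)nc2N1c1ccn(C)n1`) is still to be measured. Its difference from compound 1 is hydroxy in place of hydrogen on a saturated chain carbon, three bonds along the chain from a sulfonamide nitrogen and amounts to propyl becoming 3-hydroxypropyl, with the hydroxy on a saturated chain carbon, three bonds along the chain from a sulfonamide nitrogen. Going by the values given here, with no measured precedent for this change, no step beyond the scatter is expected in this assay and no direction is favoured. The expected step is a 1.1-fold higher number from compound 1 to compound 4 (0.04 log units; within the scatter) and it rests on compound 1 at 21700 nM alone. For compound 4 the estimated value is 24000 nM with an expected range of 10000 nM to 55000 nM around it.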

Compound 4, concentration for 50% growth inhibition: 25800 nM
Estimate against measurement, compound 4: 1.1-fold (0.03 log units) below; the range from low to high includes it.
By their numbers in this assay, from the lowest: compound 2; then compounds 3, 1 and 4 (each within the scatter of the next, the first and the last beyond it).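

The series now has its first measured step that differs in one place: in this assay, propyl becoming 3-hydroxypropyl gives a 1.2-fold higher number from compound 1 to compound 4 (0.08 log units; within the scatter). On a saturated chain carbon, three bonds along the chain from a sulfonamide nitrogen, the entering hydroxy adds one oxygen, one hydrogen-bond donor and one hydrogen-bond acceptor, yet no change in inhibition of growth can be read from this step. No measured information on the compounds bears on this result, and the step stands as an observation without an explanation.

Open, as far as these compounds go, is how this chain end reads with an amine, a carboxylic acid or a methoxy at the same place, or with a longer chain such as 4-hydroxybutyl, as a single hydroxy says nothing about those groups. Also open, from the compounds shown here alone, is whether the same change stays as small on other compounds, for instance on compound 2, which gives 2100 nM in this assay, as the step is known only on compound 1.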